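Replacing the trifluoromethylcyclobutyl group with 4-fluorophenyl

A few compounds are considered here, and "the series" means these few. Any claim that something is new, unique, unknown or untested is made for them only; others in the source may bear on it.

Measured in an ADME assay on Huh-7 cells (Homo sapiens) for cytotoxicity, with a stated time of 72 h; a higher number here means that more compound is tolerated, a lower number that less compound is tolerated:
- compound 1 `CC(C)CC(C)n1nc(-c2cccs2)c(O)c(C2=NS(=O)(=O)c3cc(NS(C)(=O)=O)ccc3N2)c1=O`: > 33000 nM
- compound 2 `CC(C)Cn1nc(-c2cccs2)c(O)c(C2=NS(=O)(=O)c3cc(NS(C)(=O)=O)ccc3N2)c1=O`: > 1000 nM
- compound 3 `CS(=O)(=O)Nc1ccc2c(c1)S(=O)(=O)N=C(c1c(O)c(-c3cccs3)nn(CC3(C(F)(F)F)CCC3)c1=O)N2`: > 1000 nM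

All three values are limits, not numbers. Compound 3 sits at the limit of > 1000 nM in this assay, at which 2 of the 3 values shown sit. Compound 1 sits at the limit of > 33000 nM in this assay, at which 1 of the 3 values shown sits.

The next compound is compound 4 `CS(=O)(=O)Nc1ccc2c(c1)S(=O)(=O)N=C(c1c(O)c(-c3cccs3)nn(Cc3ccc(F)cc3)c1=O)N2`, and the change is 4-fluorophenyl in place of 1-(trifluoromethyl)cyclobutyl on a saturated chain carbon bound to an aromatic nitrogen. In words, this is 4-fluorophenyl in place of 1-(trifluoromethyl)cyclobutyl on a saturated chain carbon bound to an aromatic nitrogen. The same difference, cut one bond further out, reads (1-(trifluoromethyl)cyclobutyl)methyl to 4-fluorobenzyl.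

The closest measured change at this place is a step that the two limits leave unreadable from compound 2 to compound 3. Two further changes on the aromatic nitrogen bear on it: a step that the two limits leave unreadable from compound 1 to compound 2 and a step that the two limits leave unreadable from compound 1 to compound 3. None of these steps has a readable size, so they support no direction and no expected size for the new step. For the measured compounds named here, no measured compound has reached a numerical value in this assay, and compound 4 is expected to be reported as a limit too.

The estimated change is a step that the limit leaves unreadable from compound 3 to compound 4, with little weight on its size. For compound 4 the expected value is 15000 nM, with an estimated range from 2000 nM to 50000 nM.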

Compound 4, half-maximal cytotoxic concentration: > 1000 nM
Compound 4 ended at the assay's limit (the forecaster's own chance of this, stated with the estimate: 85%); the middle value lies beyond the limit too.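

In this assay compound 4 gives > 1000 nM, a limit and not a number. Its steps to compound 1, compound 2 and compound 3 cannot be read, as all four values are limits. The compounds shown leave open whether any of these groups on the aromatic nitrogen changes the half-maximal cytotoxic concentration at all.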